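Stilbene-type series: a methyl replacing a methoxy

A few compounds are considered here, and "the series" means these few. Any claim that something is new, unique, unknown or untested is made for them only; others in the source may bear on it.

Compound 1 `COCCOc1cc(/C=C/c2ccc3ccccc3c2)ccc1OC` gives > 5000 nM in a functional assay on HT-29 cells (Homo sapiens) for inhibition (on this read-out lower numbers stand for stronger inhibition and higher numbers for weaker inhibition), which is a limit of the assay.
Compound 2 `CC(=O)Oc1ccc(/C=C/c2ccc3ccccc3c2)cc1` gives > 5000 nM in this assay, again a limit.
Compound 3 `COc1ccc(/C=C/c2ccc3ccccc3c2)cc1` gives > 5000 nM in this assay, also a limit.

Within the data shown here, compound 3 stands only at a limit of the assay, as do both other measured compounds, so no compound can be ranked against another (the limit of > 5000 nM in this assay, at which 3 of the 3 values shown sit). The two steps that lead into compound 3 are a step that the two limits leave unreadable from compound 1 to compound 3 and a step that the two limits leave unreadable from compound 2 to compound 3; both run between two limits and their size cannot be read.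

Compound 4 `Cc1ccc(/C=C/c2ccc3ccccc3c2)cc1` differs from compound 3 by methyl in place of methoxy on an aromatic carbon. Among the measured compounds shown here, no measured step touches this change, and the steps that exist give no readable size, so nothing measured points towards a gain or a loss in this assay from this change.

The estimate for compound 4 is therefore anchored on compound 3 itself. Compound 4 is expected to remain at or beyond the limit of the assay, with an expected step that the limit leaves unreadable from compound 3 to compound 4. Compound 4 is expected to give about 9000 nM, within a range from 3000 nM to 30000 nM, and most likely only a limit will be reported.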

Compound 4, half-maximal inhibitory concentration: > 5000 nM
Compound 4: no number, only a limit; the forecaster's own chance of this, stated with the estimate: 85%; the middle value lies beyond the limit too.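

Compound 4 ends at a limit in this assay, like compound 1, compound 2 and compound 3, so neither step into compound 4, from compound 3 or from compound 2, can be read: the limit of > 5000 nM in this assay, at which 4 of the 4 values shown sit.

The compounds shown leave open how methyl, methoxy and acetoxy rank against one another, and which change to the shared core would give a readable inhibition value in this assay.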